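Adding a fluoro group to compound 2

The source may hold more compounds than are shown below. What is called first, only, known or untested is meant among the compounds shown, and "the series" means these compounds.

Compound 1 `O=C(CCCCCCN1C(=O)/C(=N\O)c2cc(Br)ccc21)NO`: 290 nM
Compound 2 `CO/N=C1/C(=O)N(CCCCCCC(=O)NO)c2ccccc21`: 730 nM

Of the compounds shown here, two have been measured in a functional assay on SW-620 cells (Homo sapiens) for antiproliferative activity, read by sulforhodamine B assay, with a stated time of 48 h; on this read-out lower numbers stand for stronger inhibition and higher numbers for weaker inhibition. Compound 2 gives 730 nM, the higher of the two numbers, while compound 1, at 290 nM, lies lower by more than the usual scatter. Compound 2 is therefore the weaker of this pair, though two values alone place it no further than that.

The next compound, compound 3 `CO/N=C1/C(=O)N(CCCCCCC(=O)NO)c2ccc(F)cc21`, keeps everything in compound 2 except for one place: fluoro in place of hydrogen on an aromatic carbon. Within the data shown here, no measured pair in this set differs in only one place, so the data offer no direct precedent for the size of this step. A change this small is expected to shift the number slightly downward, if at all, and not beyond the scatter. The expected move is a 1.4-fold lower number from compound 2 to compound 3 (0.15 log units; within the scatter), an estimate that remains tentative. In this assay, compound 3 is estimated at 520 nM, with an expected range from 220 nM to 1200 nM.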

Compound 3, half-maximal inhibitory concentration: 1110 nM
The estimate for compound 3 lay 2.1-fold (0.33 log units) below the measured number, and the stated range covers the measured number.
By their numbers in this assay, from the lowest: compound 1; then compounds 2 and 3 (each within the scatter of the next).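

In this assay, among these compounds, fluoro in place of hydrogen on an aromatic carbon gives a 1.5-fold higher number from compound 2 to compound 3 (0.18 log units; within the scatter), the first step in this set between compounds that differ in only one place. The step shows that this position, on a six-membered aromatic ring of carbon only, meta to a fused ring and para to a fused ring, can carry fluoro without a change that can be told apart from the usual variation between repeated measurements. No available measurement bears on why the step has this size.

From the compounds shown here alone, a single small substituent at one position cannot show how far this tolerance extends, so it remains open whether a chloro group, a nitrile, an amine or a methoxy group at the same carbon would stay within the scatter or move the number beyond it. Going by these compounds, it also remains open whether fluoro on another carbon of that ring would give a step of similar size, or whether the same exchange would behave alike on the core of compound 1.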